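The compounds below may be only part of what the source reports. "The series", "measured", "known", "first", "only" and "open" are said of these compounds alone.

Measured compounds:
compound 1 `COc1ccc(/C=C/C(=O)c2c(C)cc(O)c(C(=O)/C=C/c3ccc(OC)cc3)c2-c2ccc(OCc3ccccc3)cc2)cc1` — 12000 nM
compound 2 `Cc1cc(O)c(C(=O)/C=C/c2ccc(F)cc2)c(-c2ccc(OCc3ccccc3)cc2)c1C(=O)/C=C/c1ccc(F)cc1` — 15000 nM
compound 3 `Cc1cc(O)c(C(=O)/C=C/c2ccc(OCc3ccccc3)cc2)c(-c2ccccc2)c1C(=O)/C=C/c1ccc(OCc2ccccc2)cc1` — 10000 nM

All three values come from a functional assay on MDA-MB-231 cells (Homo sapiens) for cytotoxicity, read by MTT assay, with a stated time of 24 h; on this read-out lower numbers stand for stronger inhibition and higher numbers for weaker inhibition. Compound 1 sits second highest of the three numbers; its gap to compound 3 and its gap to compound 2 both lie within the scatter, so the three compounds are not separated by this assay.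

Compound 4 `COc1ccc(/C=C/C(=O)c2c(C)cc(O)c(C(=O)/C=C/c3ccc(OC)cc3)c2-c2ccccc2)cc1` differs from compound 1 in one place: hydrogen in place of benzyloxy on an aromatic carbon. Going by the values given here, no measured pair shows this step on its own. Given how closely compounds 1, 2 and 3 cluster, the step from compound 1 to compound 4 is expected to stay within the scatter, as no change at the digits printed from compound 1 to compound 4 (within the scatter). Compound 4 is therefore estimated at 12000 nM, with a range of 6000 nM to 25000 nM.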

Compound 4, half-maximal inhibitory concentration: "not active" (no number reported)
Nothing numeric was reported for compound 4, so the estimate cannot be set against anything.
By their numbers in this assay, from the lowest: compounds 3, 1 and 2 (each within the scatter of the next).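

Going by these compounds alone, compound 4 is reported only as "not active", without a number, in this assay, so no step from compound 1 to compound 4 can be read. The compounds shown leave open what replacing benzyloxy with hydrogen does to the value. No measured evidence bears on this result.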